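Trimethoxyphenyl pyrazole chalcones: aryl ketone swaps

The source may hold more compounds than are shown below. What is called first, only, known or untested is meant among the compounds shown, and "the series" means these compounds.

Two compounds in this series carry the measurement that matters here. Compound 1 `COc1cc(-c2cc(/C=C/C(=O)c3ccc(Cl)c(Cl)c3)[nH]n2)cc(OC)c1OC` and compound 2 `COc1ccc(C(=O)/C=C/c2cc(-c3cc(OC)c(OC)c(OC)c3)n[nH]2)cc1OC` share the same core and differ only in the aryl group on the carbonyl carbon. For the measured compounds named here, in a functional assay on MOLT-4 cells (Homo sapiens) for cytotoxicity, read by sulforhodamine B assay, with a stated time of 48 h, tested at 1 uM (on this read-out higher numbers stand for a weaker effect at the one concentration tested and lower numbers for a stronger effect), compound 1 gives 97%, and compound 2 gives 88%; the two numbers sit within the scatter of each other, and the one step available, a number 9 percentage points lower from compound 1 to compound 2 (within the scatter), bears directly on the next change. Compound 3 `COc1cc(-c2cc(/C=C/C(=O)c3ccc(F)c(F)c3)[nH]n2)cc(OC)c1OC` differs from compound 2 by 3,4-difluorophenyl in place of 3,4-dimethoxyphenyl on a carbonyl carbon. Going by the values given here, the only related step is the exchange of one aryl ring for another at this same carbonyl carbon, and that step did not move the read-out beyond the scatter. The expected change, a number 4 percentage points higher from compound 2 to compound 3 (within the scatter), is therefore none beyond the scatter. For compound 3 the estimate in this assay is 92%, expected between 76% and 104%.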

Compound 3, a percentage reported as activity, at one concentration (the size of the read-out at that concentration, not a potency): 91%
Compound 3: the middle estimate sits 1 percentage points above what was measured; the range from low to high includes it.
By their numbers in this assay, from the lowest: compounds 2, 3 and 1 (each within the scatter of the next).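

At the aryl group on a carbonyl carbon, the series now holds three rings in this assay, and 3,4-difluorophenyl shows a number 3 percentage points higher from compound 2 to compound 3 (within the scatter) and a number 6 percentage points lower from compound 1 to compound 3 (within the scatter). Where one pair gave a single exchange, the 3,4-dichlorophenyl, 3,4-dimethoxyphenyl and 3,4-difluorophenyl compounds now all lie within the scatter of one another, so no order among these three groups can be read at this position. Nothing at hand bears on what lies behind this result.

On these data alone, whether a ring carrying a dimethylamino group or a carboxylic acid, or a longer alkyl chain in place of the ring, would give a read-out outside the scatter of these three stays open. A single concentration also leaves open whether these compounds differ in potency.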